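The source may hold more compounds than are shown below. What is called first, only, known or untested is meant among the compounds shown, and "the series" means these compounds.

Three measured compounds share one core. Compound 1 `COc1ccc(S(=O)(=O)N2CCc3cccc(-c4ccc(N(C)C)cc4)c32)cc1` carries a 4-(dimethylamino)phenyl group on that core, and in a functional assay on NCI-H460 cells (Homo sapiens) for inhibition, with a stated time of 72 h (on this read-out lower numbers stand for stronger inhibition and higher numbers for weaker inhibition), compound 1 gives 556 nM. Compound 2 `COc1ccc(S(=O)(=O)n2ccc3cccc(-c4ccc(C#N)cc4)c32)cc1` gives 172 nM, while compound 3 `COc1ccc(S(=O)(=O)n2ccc3cccc(-c4ccc(F)cc4)c32)cc1` gives 212 nM. Compound 1 therefore stands as the highest number of the three, beyond the scatter from both compound 2 and compound 3, which makes it the weakest inhibitor in this small set.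

Among the measured compounds shown here, only one pair of measured compounds differs in a single place: a 1.2-fold higher number from compound 2 to compound 3 (0.09 log units; within the scatter). Exchanging one small group for another on the outer aromatic ring left the read-out essentially where it was. For the measured compounds named here, compounds 2 and 3 also differ from compound 1 in the core itself, so no measured step speaks directly to the outer group of compound 1.

Compound 4 `COc1ccc(S(=O)(=O)N2CCc3cccc(-c4cccs4)c32)cc1` has not yet been measured. Compared with compound 1, the change is thiophen-2-yl in place of 4-(dimethylamino)phenyl on an aromatic carbon. Going by the values given here, this exchanges the whole outer aromatic group, not one substituent on it, so the single measured step offers only loose guidance. The expectation is therefore a step of about a 1.1-fold lower number from compound 1 to compound 4 (0.05 log units; within the scatter), with no direction strongly favoured. For compound 4 the estimated value in this assay is 500 nM, with a range from 180 nM to 1400 nM.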

Compound 4, half-maximal inhibitory concentration: 229 nM
Beside the measured number, compound 4's estimate is 2.2-fold (0.34 log units) above it, and the stated range covers the measured number.
By their numbers in this assay, from the lowest: compounds 2, 3 and 4 (each within the scatter of the next); then compound 1.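

Among the compounds shown here, this result gives the first measured step on the core of compound 1, and it shows that the group on this aromatic carbon, ortho to a fused ring, can move the read-out: in this assay there is a 2.4-fold lower number from compound 1 to compound 4 (0.39 log units; beyond the scatter) when thiophen-2-yl enters in place of 4-(dimethylamino)phenyl. The earlier single-place step, a 1.2-fold higher number from compound 2 to compound 3 (0.09 log units; within the scatter), stayed within the scatter, but it exchanged one small substituent on the outer ring of a different core, whereas this change replaces the whole outer group and goes beyond the scatter. No measurement here explains why the exchange lowers the number, so the step records an outcome and not a cause.

The exchange alters several things together, with a six-membered carbon ring and its dimethylamino group leaving and a five-membered sulfur-containing ring entering, so the compounds shown cannot say which of these changes matters. A plain phenyl group on the core of compound 1 would separate the loss of the dimethylamino group from the change of ring, and a furan-2-yl group would test whether the sulfur atom of the five-membered ring matters.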